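Side-chain change on compound 1

The source may hold more compounds than are shown below. What is called first, only, known or untested is meant among the compounds shown, and "the series" means these compounds.

Within the data shown here, in an ADME assay on microsomes from liver (Mus musculus) for metabolic stability, read by LC-MS, with a stated time of 10 min, tested at 0.5 uM (a higher number here means that more of the compound is left, a lower number that less of the compound is left), compound 1 (`c1ccc2c(c1)CN[C@@H](CN(CCC1CCNCC1)[C@H]1CCCc3cccnc31)C2`) gives 32%, the lower of the two numbers so far. Compound 2 (`c1cnc2c(c1)CN[C@H](CN(CCCN1CCNCC1)[C@H]1CCCc3cccnc31)C2`) gives 63%, higher by more than the usual scatter. Compound 3 (`CN1CCN(CCCN(C[C@H]2Cc3ccccc3CN2)[C@H]2CCCc3cccnc32)CC1`) differs from compound 1 by one change: (4-methylpiperazin-1-yl)methyl in place of piperidin-4-yl on a saturated chain carbon, two bonds along the chain from an amine nitrogen. Among the measured compounds shown here, no measured pair isolates this change, so its effect is uncertain. A modest upward step is expected, possibly within the scatter, with compound 2 at 63% as the only higher reference. The estimated step is a number 13 percentage points higher from compound 1 to compound 3 (beyond the scatter). For compound 3, the expected value is 45%, with an estimated range of 25% to 68%.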

Compound 3, percent of the compound remaining: 53%
The estimate for compound 3 lay 8 percentage points below the measured number; the measured number falls inside the stated range.
By their numbers in this assay, from the lowest: compound 1; then compounds 3 and 2 (each within the scatter of the next).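

Swapping piperidin-4-yl for (4-methylpiperazin-1-yl)methyl on a saturated chain carbon, two bonds along the chain from an amine nitrogen, gives the first single-change reading at this position: in this assay, the percent remaining is a number 21 percentage points higher from compound 1 to compound 3 (beyond the scatter). This position therefore tolerates a larger side chain in this assay without loss of the compound remaining. No measurement at hand accounts for the step.

Still open, from the compounds shown here alone, is whether the second ring nitrogen, the methyl or the longer chain carries the step. A (morpholin-4-yl)methyl group at this place would help separate these.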